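The source may report more compounds than this note shows. Statements on the series, on what has been measured and on what is new or still open speak of the compounds shown alone.

Going by the values given here, in a functional assay on MGC-803 cells (Homo sapiens) for inhibition, read by MTT assay, with a stated time of 72 h (a lower number here means a stronger inhibitor, a higher number a weaker inhibitor), three compounds have numbers so far. Compound 1 `CN1CCN(c2cc(C(F)(F)F)nc(SCc3ccc(C(F)(F)F)cc3)n2)CC1` gives 15800 nM, the lowest of the three and so the strongest inhibitor among them. Compound 2 `FC(F)(F)c1ccc(CSc2nc(N3CCN(c4ccccc4)CC3)cc(C(F)(F)F)n2)cc1` gives 35200 nM. Compound 3 `FC(F)(F)c1ccc(CSc2nc(N3CCN(c4ncccn4)CC3)cc(C(F)(F)F)n2)cc1` gives 35200 nM. Putting phenyl in place of methyl on the amine nitrogen in the ring is a 2.2-fold higher number from compound 1 to compound 2 (0.35 log units; beyond the scatter), and putting pyrimidin-2-yl there is a 2.2-fold higher number from compound 1 to compound 3 (0.35 log units; beyond the scatter). Exchanging the two aromatic rings is no change at the digits printed from compound 2 to compound 3 (within the scatter).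

Compound 4 `FC(F)(F)c1ccc(CSc2nc(Sc3ncccn3)cc(C(F)(F)F)n2)cc1` changes more: (pyrimidin-2-yl)sulfanyl stands in place of 4-methylpiperazin-1-yl on an aromatic carbon, ((pyrimidin-2-yl)sulfanyl in place of 4-methylpiperazin-1-yl on an aromatic carbon). Among the compounds with values here, no measured step makes this exact exchange, so the evidence is indirect. The nearest guides are the two modest rises above, a 2.2-fold higher number from compound 1 to compound 2 (0.35 log units; beyond the scatter) and a 2.2-fold higher number from compound 1 to compound 3 (0.35 log units; beyond the scatter), in which an aromatic ring replaced methyl. A similar modest move towards a weaker number is therefore expected, though with wide uncertainty. The expected step is a 1.9-fold higher number from compound 1 to compound 4 (0.28 log units; within the scatter). The estimated value for compound 4 is 30000 nM, with an expected range of 11000 nM to 80000 nM.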

Compound 4, half-maximal inhibitory concentration: 28600 nM
Beside the measured number, compound 4's estimate is 1.0-fold (0.02 log units) above it; measured number inside the range.
By their numbers in this assay, from the lowest: compounds 1, 4, 2 and 3 (each within the scatter of the next, the first and the last beyond it).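

In this assay, (pyrimidin-2-yl)sulfanyl in place of 4-methylpiperazin-1-yl on an aromatic carbon gives a 1.8-fold higher number from compound 1 to compound 4 (0.26 log units; within the scatter). Compounds 1, 2 and 3 all keep the six-membered non-aromatic ring at this position, so they could not show that the ring and its two nitrogens can be replaced entirely, here by a sulfur-linked six-membered aromatic ring of the same heavy-atom count, with no change beyond the scatter in this cell assay. Nothing measured here explains why the two groups give numbers within the scatter of each other.

The compounds shown leave open how much the sulfur link itself contributes, which a (pyrimidin-2-yl)oxy group at the same carbon would test directly. They also leave open whether a morpholin-4-yl group or an open-chain dimethylamino group would fit this position equally well.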